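The compounds below may be only part of what the source reports. "The series", "measured", "known", "first", "only" and "open" are said of these compounds alone.

Compound 1 `CCc1ccc(/C=C/[C@@H]2CCCCN2)cc1` and compound 2 `CC(=O)c1ccc(/C=C/[C@@H]2CCCCN2)cc1` share one core and differ only in the group on the aromatic ring. In a functional assay on MCF7 cells (Homo sapiens) for inhibition, read by MTT assay, with a stated time of 24 h (a higher number here means a weaker inhibitor, a lower number a stronger inhibitor), compound 1 gives 4.13 ug/mL, the highest of the two numbers recorded, while compound 2 gives 2.7 ug/mL. Among the measured compounds shown here, the single measured step, a 1.5-fold lower number from compound 1 to compound 2 (0.18 log units; within the scatter), is acetyl in place of ethyl on an aromatic carbon, and it stays within the scatter.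

Compound 3 `Cc1ccc(/C=C/[C@@H]2CCCCN2)cc1` is the next point on the same core. Its change from compound 1 is hydrogen in place of methyl on a saturated chain carbon bound to an aromatic carbon, or read one bond further out, ethyl to methyl. For the measured compounds named here, the only measured step that touches this part of the molecule is the one from compound 1 to compound 2, which replaced the whole ethyl group and still moved the number only within the scatter. A smaller trimming of that same group is therefore expected to give no step beyond the scatter in this assay, so the expected step is a 1.1-fold higher number from compound 1 to compound 3 (0.04 log units; within the scatter). Compound 3 is accordingly estimated at 4.5 ug/mL, with a range from 2.3 ug/mL to 9 ug/mL.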

Compound 3, half-maximal inhibitory concentration: 5.35 ug/mL
Compound 3: middle estimate off by 1.2-fold (0.08 log units), on the low side; low and high end bracket the measured number.
By their numbers in this assay, from the lowest: compounds 2, 1 and 3 (each within the scatter of the next).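

Hydrogen in place of methyl on a saturated chain carbon bound to an aromatic carbon, which reads one bond further out as ethyl to methyl, gives a 1.3-fold higher number from compound 1 to compound 3 (0.11 log units; within the scatter) in this assay. This position has now been tested with a trimming of the ethyl group as well as with the replacement of the whole group, and neither change leaves the scatter. The new compound also sets methyl directly against acetyl: methyl in place of acetyl on an aromatic carbon gives a 2.0-fold higher number from compound 2 to compound 3 (0.30 log units; within the scatter), the largest step among these three compounds but still printed as within the scatter, so ethyl, methyl and acetyl cannot be told apart at this position in this assay.

From the compounds shown here alone, whether a different kind of group on the aromatic ring, such as an amine, a carboxylic acid or a longer chain such as hexyl, would produce a step beyond the scatter remains open. Nothing else measured here bears on these small differences among the three compounds.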